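This account rests on a few compounds, and the source may have more. Where it says the series, first, only, none or still open, it means among the compounds named here.

Working notes on the series. Compound 1 `ClCc1ccccc1Cn1cnc2c(Cl)nc(Cl)nc21`, compound 2 `ClCc1ccccc1Cn1cnc2c(Cl)ncnc21`, compound 3 `ClCc1ccccc1Cn1cnc2ncnc(Cl)c21` and compound 4 `ClCc1ccccc1Cn1cnc2nc(Cl)nc(Cl)c21` differ only in their fused cores. In a functional assay on NCI-H226 cells (Homo sapiens) for cytotoxicity, read by sulforhodamine B assay, with a stated time of 48 h (on this read-out higher numbers stand for lower toxicity in this test and lower numbers for higher toxicity in this test), compound 1 gives 6760 nM, while compound 2 gives 38900 nM. The change from compound 2 to compound 1 is chloro in place of hydrogen on an aromatic carbon, and it brought a 5.8-fold lower number from compound 2 to compound 1 (0.76 log units; beyond the scatter). Compound 3 reaches only a limit in this assay, > 100000 nM; (the limit of > 100000 nM in this assay, at which 1 of the 3 values shown sits). The difference between the core of compound 2 and the core of compound 3 is not broken down here. Compound 4 carries the same change made on compound 3, (chloro in place of hydrogen on an aromatic carbon), with the surroundings of the place described in identical words, so it counts as the same change. The step is expected to echo the earlier one, an at least 3.3-fold lower number from compound 3 to compound 4 (0.52 log units; beyond the scatter), resting on a 5.8-fold lower number from compound 2 to compound 1 (0.76 log units; beyond the scatter). Compound 3 stands at a limit, which leaves the estimate for compound 4 wide: 30000 nM, from 8000 nM to 150000 nM.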

Compound 4, concentration lethal to 50% of the cells: 28200 nM
The estimate for compound 4 lay 1.1-fold (0.03 log units) above the measured number, within the range that was stated.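

In this assay, chloro in place of hydrogen on an aromatic carbon lowers the number on a second core as well, with an at least 3.5-fold lower number from compound 3 to compound 4 (0.54 log units; beyond the scatter). The direction therefore carries across these two cores, but the comparison of size stays unsettled: the same change on two cores in this assay, a 5.8-fold lower number (0.76 log units; beyond the scatter) from compound 2 to compound 1 and an at least 3.5-fold lower number (0.54 log units; beyond the scatter) from compound 3 to compound 4; the limit leaves it open whether they differ The step from compound 3 rests on a limit of the assay and not on a number, so its true size is not known: the limit of > 100000 nM in this assay, at which 1 of the 4 values shown sits.

Two pairs cannot show whether the direction holds on any further core. Also open, as far as these compounds go, is whether an amine or a methoxy group in place of the chloro would move the number in the same direction.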